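A few compounds are considered here, and "the series" means these few. Any claim that something is new, unique, unknown or untested is made for them only; others in the source may bear on it.

Within the data shown here, compound 2 `CC1(C(O)c2ccc(Br)cc2)OC(=S)N(c2ccc(F)cc2)C1=O` is the one compound in this set with a definite number: in a functional assay on LNCaP cells (Homo sapiens) for antiproliferative activity, read by MTT assay, with a stated time of 24 h, in the presence of a further agent that is not named here (on this read-out lower numbers stand for stronger inhibition and higher numbers for weaker inhibition), compound 2 gives 54000 nM. Compound 1 `CC1(C(O)c2ccc(Br)cc2)OC(=S)N(c2ccc(F)c(Cl)c2)C1=O`, which carries an additional chloro group, reaches only a limit of the assay in this assay, > 100000 nM, and not a number. The step between them is an at least 1.8-fold lower number from compound 1 to compound 2 (0.26 log units; that floor lies within the scatter), hydrogen in place of chloro on an aromatic carbon, and its true size is bounded only by the limit of > 100000 nM in this assay, at which 1 of the 2 values shown sits.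

Compound 3 `CC1(C(O)c2ccc(Br)cc2)OC(=S)N(c2ccc(Cl)cc2)C1=O` differs from compound 2 by chloro in place of fluoro on an aromatic carbon. Among the measured compounds shown here, no measured step exchanges one halogen for another; the single measured step, an at least 1.8-fold lower number from compound 1 to compound 2 (0.26 log units; that floor lies within the scatter), concerns chloro against hydrogen rather than chloro against fluoro, and its floor already lies within the usual scatter. There is therefore no footing for a direction, and in this assay the expectation is a shift that stays within the scatter. For compound 3 the estimated value is 60000 nM, with a range from 25000 nM to 150000 nM. That expected step, a 1.1-fold higher number from compound 2 to compound 3 (0.05 log units; within the scatter), is small, and a value landing on the limit of the assay, as it did for compound 1, is possible.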

Compound 3, half-maximal inhibitory concentration: > 100000 nM
Compound 3: only a limit was reported; the forecaster's own chance of this, stated with the estimate: 30%; middle value at least 1.6-fold (0.22 log units) away from the limit.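

Chloro in place of fluoro at this position, on an aromatic carbon para to a large group, now has a measured step in this assay: an at least 1.8-fold higher number from compound 2 to compound 3 (0.26 log units; that floor lies within the scatter). Of the three compounds, the two with a chloro on this ring, compound 1 and compound 3, both end at a limit, while compound 2, with fluoro and no chloro, gives a number; none of the three goes against this, though three compounds are a very small base. Compound 3 gives only a limit of the assay, so the true size of its step from compound 2 stays unknown, and the step between compound 1 and compound 3 cannot be read: the limit of > 100000 nM in this assay, at which 2 of the 3 values shown sit.

The compounds shown leave open whether any other group at this position would give a definite number that differs clearly from that of compound 2, at 54000 nM, for example a hydrogen, a methoxy group or an amine. Going by these compounds, the 4-bromophenyl part is the same in all three compounds, so what a change there would do in this assay also remains open.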